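Swapping cyano for acetamido in a flat series

A few compounds are considered here, and "the series" means these few. Any claim that something is new, unique, unknown or untested is made for them only; others in the source may bear on it.

Of the compounds shown here, three sharing one core have been measured in a functional assay on QGY-7703 cells (Homo sapiens) for cytotoxicity, read by MTT assay, with a stated time of 24 h; on this read-out higher numbers stand for weaker inhibition and lower numbers for stronger inhibition. Compound 1 (`O=C1/C(=C/c2ccncc2)CN(S(=O)(=O)c2ccc(C(F)(F)F)cc2)C/C1=C\c1ccccc1F`) gives 9500 nM with trifluoromethyl on an aromatic carbon. Compound 2 (`O=C1/C(=C/c2ccncc2)CN(S(=O)(=O)c2ccc(Br)cc2)C/C1=C\c1ccccc1F`) gives 11500 nM with bromo at that place. Compound 3 (`N#Cc1ccc(S(=O)(=O)N2C/C(=C\c3ccncc3)C(=O)/C(=C/c3ccccc3F)C2)cc1`) gives 8500 nM with cyano there, which leaves it level with the other two, since every gap among them lies within the scatter.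

Compound 4 (`CC(=O)Nc1ccc(S(=O)(=O)N2C/C(=C\c3ccncc3)C(=O)/C(=C/c3ccccc3F)C2)cc1`) has not been measured yet. It carries acetamido in place of cyano on an aromatic carbon, para to a large group (acetamido in place of cyano on an aromatic carbon).

The expectation rests on three measured swaps at this same place: a 1.2-fold higher number from compound 1 to compound 2 (0.08 log units; within the scatter) for bromo in place of trifluoromethyl, a 1.1-fold lower number from compound 1 to compound 3 (0.05 log units; within the scatter) for cyano in place of trifluoromethyl, and a 1.4-fold lower number from compound 2 to compound 3 (0.13 log units; within the scatter) for cyano in place of bromo. Each stayed within the scatter, so acetamido is expected to move the number no further. Among the measured compounds shown here, no measured compound carries acetamido, however, so the range is kept wide. The estimated change is a 1.2-fold higher number from compound 3 to compound 4 (0.07 log units; within the scatter) and nothing beyond the scatter is expected in this assay. Compound 4 is estimated at 10000 nM with an expected range from 5000 nM to 20000 nM in this read-out.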

Compound 4, half-maximal inhibitory concentration: 13700 nM
Beside the measured number, compound 4's estimate is 1.4-fold (0.14 log units) below it; low and high end bracket the measured number.
By their numbers in this assay, from the lowest: compounds 3, 1, 2 and 4 (each within the scatter of the next).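

In this assay, the step from cyano to acetamido brings in 4 heavy atoms in place of 2 and 1 hydrogen-bond donor in place of 0, and its size stays within the scatter (a 1.6-fold higher number from compound 3 to compound 4 (0.21 log units; within the scatter)). The comparisons with the other two groups also stay within the scatter (a 1.2-fold higher number from compound 2 to compound 4 (0.08 log units; within the scatter); a 1.4-fold higher number from compound 1 to compound 4 (0.16 log units; within the scatter)), so this position on the aromatic ring has now held four different groups, including one with an amide hydrogen, and the four compounds remain level. Nothing available explains why these swaps leave the read-out level.

A primary amine, a carboxylic acid or a longer chain at this same place might stay level with these four compounds or might step beyond the scatter, and the compounds shown cannot tell which. As far as these compounds go, all four also share the rest of their structure, so it remains open whether changes elsewhere on the shared core would move the read-out more than changes at this position have.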